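Cytotoxicity notes: exchanging the amine on the propargyl arm

The source may report more compounds than this note shows. Statements on the series, on what has been measured and on what is new or still open speak of the compounds shown alone.

Compound 1 `CN1CCN(CC#Cc2cc3ncnc(Nc4ccc(OCc5cccc(F)c5)c(Cl)c4)c3s2)CC1` gives 11 uM in an ADME assay on HepG2 cells (Homo sapiens) for cytotoxicity; a lower number here means that less compound is tolerated, a higher number that more compound is tolerated. Compound 2 `CCOC(=O)CN(C)CC#Cc1cc2ncnc(Nc3ccc(OCc4cccc(F)c4)c(Cl)c3)c2s1` carries ((ethoxycarbonyl)methyl)(methyl)amino in place of 4-methylpiperazin-1-yl on a saturated chain carbon bound to a triple-bonded carbon and gives 26 uM in this assay, so the change made a 2.4-fold higher number from compound 1 to compound 2 (0.37 log units; beyond the scatter). Compound 3 `CN1CCN(CC#Cc2cc3c(Nc4ccc(OCc5cccc(F)c5)c(Cl)c4)ncnc3s2)CC1` has the same atoms as compound 1 joined differently; the difference between the two cores is not broken down here. In this assay compound 3 gives 15 uM, which sits within the scatter of both compound 1 and compound 2.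

Compound 4 `CCOC(=O)CN(C)CC#Cc1cc2c(Nc3ccc(OCc4cccc(F)c4)c(Cl)c3)ncnc2s1` is not yet measured. It differs from compound 3 by ((ethoxycarbonyl)methyl)(methyl)amino in place of 4-methylpiperazin-1-yl on a saturated chain carbon bound to a triple-bonded carbon, the same change, at the same place, that separates compound 2 from compound 1; it occurs twice among these four compounds. The expectation for the step of a 2.1-fold higher number from compound 3 to compound 4 (0.33 log units; beyond the scatter) is estimated to be of the same size because the same change gave a 2.4-fold higher number from compound 1 to compound 2 (0.37 log units; beyond the scatter). Compound 4 is therefore expected to give 32 uM in this assay, with the likely range running from 16 uM to 64 uM. Whether the step transfers across the two cores remains to be seen.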

Compound 4, half-maximal toxic concentration: > 28 uM
Compound 4 was reported as a limit; the forecaster's own chance of this, stated with the estimate: 5%; the middle value is on the limit's open side.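

Compound 4 is reported in this assay only as a limit, > 28 uM. The new step therefore gives a floor and not a size: an at least 1.8-fold higher number from compound 3 to compound 4 (0.27 log units; that floor lies within the scatter). The change raises the number on the core of compound 1 by an amount beyond the scatter, and on the core of compound 3 the number also goes up, but that floor does not show a step beyond the scatter, so the notes support the same direction without showing that the size carries over from one core to the other: the same change on two cores in this assay, a 2.4-fold higher number (0.37 log units; beyond the scatter) from compound 1 to compound 2 and an at least 1.8-fold higher number (0.27 log units; that floor lies within the scatter) from compound 3 to compound 4; the limit leaves it open whether they differ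

Still open, on these data alone, is how large the step is on the core of compound 3, a question that only a number for compound 4 in place of the limit could settle. Also open, as far as these compounds go, is how a free carboxylic acid in place of the ethyl ester, or a morpholine in place of 4-methylpiperazin-1-yl, would read on either core.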